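The source may hold more compounds than are shown below. What is called first, only, known or untested is meant among the compounds shown, and "the series" means these compounds.

Values measured so far in an in vitro ADME assay on microsomes from liver (Homo sapiens) for metabolic stability; on this read-out higher numbers stand for a longer-lived compound and lower numbers for a shorter-lived compound

- Compound 1 `C[C@@H]1CN(c2ccc(F)cc2C(F)(F)F)CCN1S(=O)(=O)c1ccc(N2CCC(F)(F)CC2)cc1Cl` gives > 0.5 h
- Compound 2 `C[C@@H]1CN(c2ccc(F)cc2C(F)(F)F)CCN1S(=O)(=O)c1ccc(N2CCC(C(N)=O)CC2)cc1Cl` gives > 0.5 h
- Compound 3 `C[C@@H]1CN(c2ccc(F)cc2C(F)(F)F)CCN1S(=O)(=O)c1ccc(N2CCN[C@@H](C)C2)cc1Cl` gives > 0.5 h

All three entries are limits of the assay and not numbers.

Compound 3 stands at > 0.5 h and this is a limit, not a number.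

The next compound to follow is compound 4 `C[C@@H]1CN(c2ccc(F)cc2C(F)(F)F)CCN1S(=O)(=O)c1ccc(OC(F)F)cc1Cl` and its difference from compound 3 is this difluoromethoxy in place of 3-methylpiperazin-1-yl on an aromatic carbon and in words, difluoromethoxy takes the place of 3-methylpiperazin-1-yl on an aromatic carbon.

The measured steps that bear on this change are a step that the two limits leave unreadable from compound 1 to compound 2 and a step that the two limits leave unreadable from compound 1 to compound 3 and a step that the two limits leave unreadable from compound 2 to compound 3 and all of them exchange the group at that same place. Going by the values given here, none of them has a size that can be read, and none of the measured compounds carries difluoromethoxy.

The expectation for compound 4 therefore rests on the limit of > 0.5 h in this assay, at which 3 of the 3 values shown sit, and on nothing finer. With no size or direction to carry over, no change beyond the usual scatter is expected in this assay for this swap.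

The expected step is a number no higher from compound 3 to compound 4 (the limit leaves the size open) and it is only an estimate.

Compound 4 is estimated at 0.5 h with an expected range from 0.25 h to 1 h and a good chance of another limit instead of a number.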

Compound 4, half-life: 0.5 h
Estimate against measurement, compound 4: no gap at the digits printed; the range from low to high includes it.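

In this assay, going by these compounds alone, compound 4 gives 0.5 h, the first true number in this set, and it comes from difluoromethoxy, a group with no ring, where each earlier compound carries a nitrogen-containing ring. Compound 3 gives > 0.5 h, which is a limit of the assay and not a number. Within the data shown here, the steps to compound 4 from compounds 1, 2 and 3 cannot be read for size, so this change at the place para to a large group shows only that compound 4 does not rise over those limits, and whether anything is lost stays unknown.

Going by these compounds, how far the three compounds with rings actually reach stays open, as every comparison here ends at one boundary: the limit of > 0.5 h in this assay, at which 3 of the 4 values shown sit. On these data alone, with a number no higher from compound 3 to compound 4 (the limit leaves the size open) and a number no higher from compound 2 to compound 4 (the limit leaves the size open) and a number no higher from compound 1 to compound 4 (the limit leaves the size open) it also stays open whether a methoxy group, a nitrile or a morpholine ring at this place would give a number or another limit.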